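Shortening a Chain on Two Related Cores

The source may report more compounds than this note shows. Statements on the series, on what has been measured and on what is new or still open speak of the compounds shown alone.

In a functional assay on A549 cells (Homo sapiens) for antiproliferative activity, read by MTT assay, with a stated time of 96 h (on this read-out lower numbers stand for stronger inhibition of growth and higher numbers for weaker inhibition of growth), compound 1 `CCCc1cc(-c2ccc(F)cc2)nn1Cc1ccc(C(=O)NO)cc1` gives 15200 nM, and compound 2 `CCc1cc(-c2ccc(F)cc2)nn1Cc1ccc(C(=O)NO)cc1` gives 19200 nM. The change between them, (hydrogen in place of methyl on a saturated chain carbon, two bonds along the chain from an aromatic carbon), produced the step of a 1.3-fold higher number from compound 1 to compound 2 (0.10 log units; within the scatter). Compound 3 `CCCc1cc(-c2ccc(F)cc2)n(Cc2ccc(C(=O)NO)cc2)n1` is built from the same atoms as compound 1 joined differently; the difference between the two cores is not broken down here. In this assay compound 3 gives 16000 nM. Compound 4 `CCc1cc(-c2ccc(F)cc2)n(Cc2ccc(C(=O)NO)cc2)n1` has not yet been measured; it differs from compound 3 by hydrogen in place of methyl on a saturated chain carbon, two bonds along the chain from an aromatic carbon, the same change as between compound 1 and compound 2, made in the same place. Among the measured compounds shown here, the step expected is a 1.3-fold higher number from compound 3 to compound 4 (0.10 log units; within the scatter), because of a 1.3-fold higher number from compound 1 to compound 2 (0.10 log units; within the scatter) as the only guide to this change. Compound 4 is therefore estimated at 20000 nM, with a range from 12000 nM to 35000 nM.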

Compound 4, concentration for 50% growth inhibition: 16700 nM
Beside the measured number, compound 4's estimate is 1.2-fold (0.08 log units) above it; measured number inside the range.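

On the core of compound 3, going from propyl to ethyl gave a 1.0-fold higher number from compound 3 to compound 4 (0.02 log units; within the scatter) in this assay. Set beside the same change on the core of compound 1, the two steps cannot be told apart: the same change on two cores in this assay, a 1.3-fold higher number (0.10 log units; within the scatter) from compound 1 to compound 2 and a 1.0-fold higher number (0.02 log units; within the scatter) from compound 3 to compound 4, 1.2-fold (0.08 log units) apart, within the scatter of two such steps. This shows that, for these four compounds, the change stays within the scatter on both cores, but it does not show that the two cores would respond alike to a change with a larger effect, and neither step here gives a size that could be carried from one core to the other.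

Going by these compounds, what a longer chain, an amine or a carboxylic acid in place of the propyl would do on either core remains open.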